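The compounds below may be only part of what the source reports. "The series", "measured", "known", "first", "only" and "open" are said of these compounds alone.

Two compounds share one core and differ only in the aryl group attached to a saturated chain carbon bound to an aromatic carbon and a nitrogen on an aromatic ring. Compound 1 `Cc1ccnc(NC(c2ccc3cccnc3c2O)c2c(F)cccc2Cl)c1` carries a 2-chloro-6-fluorophenyl there. In an assay for inhibition of protein disulfide-isomerase (Homo sapiens), with a stated time of 1 h (on this read-out lower numbers stand for stronger inhibition and higher numbers for weaker inhibition), compound 1 gives > 40000 nM, which is a limit of the assay and not a number. Compound 2 `Cc1ccnc(NC(c2cc(C)ccc2C)c2ccc3cccnc3c2O)c1` carries a 2,5-dimethylphenyl in the same place. In this assay compound 2 gives > 40000 nM, again a limit and not a number. The step that the two limits leave unreadable from compound 1 to compound 2 can therefore not be read. Compound 2 thus stands at the limit, together with compound 1 (the limit of > 40000 nM in this assay, at which 2 of the 2 values shown sit). Compound 3 `Cc1ccnc(NC(c2ccc([N+](=O)[O-])cc2)c2ccc3cccnc3c2O)c1` differs from compound 2 by 4-nitrophenyl in place of 2,5-dimethylphenyl on a saturated chain carbon bound to an aromatic carbon and a nitrogen on an aromatic ring. Within the data shown here, no measured step is readable, so no size or direction can be drawn from the measured pair; the only guide is that both measured compounds sit at the limit. The expected step is a number no higher from compound 2 to compound 3 (the limit leaves the size open), meaning no change beyond the scatter. Compound 3 is estimated at 40000 nM, with a range from 15000 nM to 100000 nM, most likely again only a limit.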

Compound 3, half-maximal inhibitory concentration: 530 nM
For compound 3 the middle estimate is 75-fold (1.88 log units) above the measured one, and the stated range ends above it.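

In this assay, this position turns out to be able to change the read-out strongly: putting 4-nitrophenyl on the saturated chain carbon gives an at least 75-fold lower number from compound 2 to compound 3 (1.87 log units; beyond the scatter), and the comparison with the 2-chloro-6-fluorophenyl group gives an at least 75-fold lower number from compound 1 to compound 3 (1.87 log units; beyond the scatter). Among these compounds, compound 3 is the first compound here with a true number rather than a limit, so the shared core can reach measurable inhibition and the aryl group at this position decides whether it does. Both steps are minimum sizes, and the two compounds without a number remain at the assay's limit: the limit of > 40000 nM in this assay, at which 2 of the 3 values shown sit.

The change swaps more than one feature at once, since the 4-nitrophenyl group carries hydrogen-bond acceptors that the 2,5-dimethylphenyl group lacks and its substituent pattern also differs, so the compounds shown cannot separate the nitro group itself from where it sits on the ring. A plain phenyl, a 4-aminophenyl or a 4-carboxyphenyl group in the same place would help show whether the nitro group is needed or whether other groups also give a measurable value.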